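Amine variation on the shared core

The compounds below may be only part of what the source reports. "The series", "measured", "known", "first", "only" and "open" are said of these compounds alone.

The series shares one core, carrying a cyclic amine on a saturated ring carbon. Compound 2 `Cc1nn([C@H](C)c2ccc(Cl)cc2Cl)c2nc(N3CC[C@H](N4CCC[C@H]4C(N)=O)[C@H](C)C3)cnc12` bears a 2-carbamoylpyrrolidin-1-yl group there; in a functional assay on cells for antagonist activity at C-C chemokine receptor type 4 (Homo sapiens), read by fluorescence and calcium flux, with stated times of 2.5 s and 45 s (on this read-out higher numbers stand for weaker inhibition and lower numbers for stronger inhibition), compound 2 gives 170 nM. Compound 1 `Cc1nn([C@H](C)c2ccc(Cl)cc2Cl)c2nc(N3CC[C@H](N4CCCC4)[C@H](C)C3)cnc12` carries the plain pyrrolidin-1-yl group, and in this assay compound 1 gives 69 nM. Going by the values given here, of the two numbers compound 2 has the higher, the single step between them being a 2.5-fold higher number from compound 1 to compound 2 (0.39 log units; beyond the scatter).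

Compound 3 `Cc1nn([C@H](C)c2ccc(Cl)cc2Cl)c2nc(N3CC[C@H](N4CCC4)[C@H](C)C3)cnc12` is not yet measured. It differs from compound 2 by azetidin-1-yl in place of 2-carbamoylpyrrolidin-1-yl on a saturated ring carbon. Two things change at once: the carbamoyl group leaves, and the five-membered ring gives way to a four-membered one. Among the compounds with values here, only the first has a counterpart in the data, namely a 2.5-fold higher number from compound 1 to compound 2 (0.39 log units; beyond the scatter) read in reverse: losing the carbamoyl alone brought the number down by a modest step. Within the data shown here, no measured step separates a five-membered from a four-membered ring amine, so that part is unknown. For compound 3 the expected step is a 1.9-fold lower number from compound 2 to compound 3 (0.28 log units; within the scatter), a modest fall that would place it near compound 1. The estimate for compound 3 in this assay is 90 nM, with a range of 35 nM to 250 nM.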

Compound 3, half-maximal inhibitory concentration: 58 nM
Beside the measured number, compound 3's estimate is 1.6-fold (0.19 log units) above it; measured number inside the range.
By their numbers in this assay, from the lowest: compounds 3 and 1 (each within the scatter of the next); then compound 2.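

Working notes on the ring amine: in this assay, the azetidin-1-yl and pyrrolidin-1-yl groups cannot be told apart at this saturated ring carbon (a 1.2-fold lower number from compound 1 to compound 3 (0.08 log units; within the scatter)), so shortening the ring by one member leaves no readable change across this pair. Replacing 2-carbamoylpyrrolidin-1-yl directly with azetidin-1-yl gives a step beyond the scatter (a 2.9-fold lower number from compound 2 to compound 3 (0.47 log units; beyond the scatter)), which leaves compound 2 apart from both compound 1 and compound 3, the two compounds whose ring amines carry no carbamoyl group. The series therefore shows some tolerance for ring size among these two plain ring amines, while the carbamoyl-bearing ring amine stands at the higher number, and no supporting measurement on hand accounts for either observation.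

Still open, going by these compounds, is whether the flat response to ring size extends to a six-membered ring amine such as piperidin-1-yl or morpholin-4-yl, or to an open-chain amine such as dimethylamino. Also open, on these data alone, is how a carboxylic acid or a hydroxymethyl group would compare with the carbamoyl on the pyrrolidine ring, and whether a carbamoyl on the azetidine ring would give a step like the one seen on the pyrrolidine ring.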